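The source may report more compounds than this note shows. Statements on the series, on what has been measured and on what is new or still open speak of the compounds shown alone.

Compound 1 `COc1cc(N)c(Cl)cc1C(=O)NC1CCN(CCCCCCCCN2C(=O)c3ccccc3C2=O)CC1` and compound 2 `COc1cc(N)c(Cl)cc1C(=O)NC1CCN(CCCCCCCCN2CCCCC2)CC1` share the same core and differ only in the group at the end of the long chain. In a functional assay on HEK293 cells for activation of 5-hydroxytryptamine receptor 4 (Homo sapiens), read by cAMP accumulation (on this read-out lower numbers stand for smaller maximal responses and higher numbers for larger maximal responses), compound 1 gives 89%. In this assay compound 2 gives > 100%, which is a limit of the assay rather than a number; compound 2 therefore stands at the limit of > 100% in this assay, at which 1 of the 2 values shown sits, and its true value is not known. Among the compounds with values here, the one measured step, a number at least 11 percentage points higher from compound 1 to compound 2 (beyond the scatter), placed a much smaller group at that chain end and raised the maximal response. Compound 3 `COc1cc(N)c(Cl)cc1C(=O)NC1CCN(CCCCCCCCN2CCN(S(C)(=O)=O)CC2)CC1` carries 4-(methylsulfonyl)piperazin-1-yl in place of piperidin-1-yl on a saturated chain carbon, eight bonds along the chain from an amine nitrogen in a ring. This change puts more atoms and more hydrogen-bond acceptors back at the same place, so the measured step bears on it only in the reverse sense, and a move back toward the value of compound 1 seems the most likely outcome. For compound 3 the step of a number at least 5 percentage points lower from compound 2 to compound 3 (that floor lies within the scatter) is expected to be small to modest, downward. Compound 3 is estimated at 95%, with a range from 80% to 110%, and a fair chance that the assay again reports only a limit.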

Compound 3, intrinsic activity: the largest response reached, in percent of the reference agonist's: > 100%
Compound 3 was reported as a limit; the forecaster's own chance of this, stated with the estimate: 35%; at least 5 percentage points between middle value and limit.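

In this assay compound 3 gives > 100%, which is a limit of the assay and not a number. The earlier pair left open whether the higher response needed an end group as small as piperidin-1-yl, and the answer here is that it did not: 4-(methylsulfonyl)piperazin-1-yl, with 10 heavy atoms and 3 hydrogen-bond acceptors, is close in heavy-atom count to the group at the chain end of compound 1, yet the change gives a number at least 11 percentage points higher from compound 1 to compound 3 (beyond the scatter). Size alone, counted in heavy atoms, therefore does not separate the high and low responses at this place, but the step between the piperidin-1-yl and 4-(methylsulfonyl)piperazin-1-yl compounds cannot be read because both values are limits: the limit of > 100% in this assay, at which 2 of the 3 values shown sit.

Going by these compounds, the true values of compound 2 and compound 3 remain unknown, so these two end groups cannot be placed in order, and any real difference between them stays hidden. Also open, on these data alone, is how the maximal response behaves with a carboxylic acid or a simple dimethylamino group at the chain end, or with a shorter chain carrying the same rings.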